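A few compounds are considered here, and "the series" means these few. Any claim that something is new, unique, unknown or untested is made for them only; others in the source may bear on it.

Measured so far:
compound 1 `Cc1cccn2c(C(=O)c3sc(N)nc3N(C)C)cnc12` 81%
compound 2 `Cc1nc(N)sc1C(=O)c1cnc2ccccn12` 53%

The account concerns two compounds measured in a functional assay on the whole organism (strain Sprague-Dawley) for inhibition, with Rattus norvegicus as the target, read by paw edema, with stated times of 1 h and 3 h, at a dose of 50 mg/kg by the oral route; a higher number here means more inhibition at the dose given (going by the name of the read-out), a lower number less inhibition. Compound 1 `Cc1cccn2c(C(=O)c3sc(N)nc3N(C)C)cnc12` gives 81% in this assay. Compound 2 `Cc1nc(N)sc1C(=O)c1cnc2ccccn12` gives 53% in this assay. Compound 2 stands lowest of the two numbers; its nearest neighbour, compound 1, lies a good way higher, a gap beyond the scatter. Going by the values given here, the two differ in more than one place, so no single step between them can be isolated.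

Compound 3 `Cc1nc(N)sc1C(=O)c1cnc2c(C)cccn12` has not yet been measured in this assay. It is reached from compound 2 by one change: methyl in place of hydrogen on an aromatic carbon. Among the compounds with values here, no measured pair isolates this change, so the direction of the step rests only on the general standing of compound 2. A modest upward step from compound 2 to compound 3 in this assay is expected, a number 9 percentage points higher from compound 2 to compound 3 (within the scatter), though a step within the scatter cannot be ruled out. Compound 3 is estimated at 62% in this assay, with a range from 42% to 80%.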

Compound 3, a percentage reported as inhibition, in the whole organism at one dose (the size of the read-out at that dose, not a potency): 45%
Estimate against measurement, compound 3: 17 percentage points above; low and high end bracket the measured number.
By their numbers in this assay, from the lowest: compounds 3 and 2 (each within the scatter of the next); then compound 1.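

In this assay, methyl in place of hydrogen on an aromatic carbon ortho to a fused ring gives a number 8 percentage points lower from compound 2 to compound 3 (within the scatter), so at this position the two groups cannot be told apart. Going by these compounds alone, compound 3 also forms a one-place pair with compound 1, which the earlier compounds lacked: methyl in place of dimethylamino on an aromatic carbon, at a different place, gives a number 36 percentage points lower from compound 1 to compound 3 (beyond the scatter), so the higher number of compound 1 goes with its dimethylamino group. Nothing at hand gives a reason for either step.

Going by these compounds, whether another amine, such as pyrrolidine or morpholine, would match dimethylamino remains open. So does whether a methoxy group or a chlorine at the position ortho to a fused ring would behave as methyl does here.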